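The compounds below may be only part of what the source reports. "The series", "measured", "known", "first", "only" and "open" are said of these compounds alone.

Measured compounds:
- Compound 1 `CC(C)Oc1cccc(-c2ccc(C(=O)N(Cc3cccc(OCCCCCC(=O)O)c3)C(C)C)cc2)c1`: in an ADME assay on HEK293 cells (Homo sapiens) for cytotoxicity, read by CellTiter-Glo and resazurin assay, with a stated time of 72 h (a lower number here means that less compound is needed, a higher number that more compound is needed for the effect), compound 1 gives > 26000 nM, which is a limit of the assay and not a number.
- Compound 2 `CCOc1cccc(-c2ccc(C(=O)N(Cc3cccc(OCCCCCC(=O)O)c3)C(C)C)cc2)c1`: in this assay compound 2 gives > 20800 nM, again only a limit.
- Compound 3 `CC(C)N(Cc1cccc(OCCCCCC(=O)O)c1)C(=O)c1ccc(-c2ccc3c(c2)OCCO3)cc1`: in this assay compound 3 gives > 21900 nM, also only a limit.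

Going by the values given here, compound 1 thus stands at a limit of this assay; every value shown is a limit, and the limit of > 26000 nM in this assay, at which 1 of the 3 values shown sits, is the one at which compound 1 sits. The unmeasured compound 4 `CC(C)N(Cc1cccc(OCCCCCC(=O)O)c1)C(=O)c1ccc(-c2cccc(OC(F)(F)F)c2)cc1` differs from compound 1 by trifluoromethyl in place of isopropyl on an oxygen on an aromatic ring. The measured steps that alter the same part of the shared core are a step that the two limits leave unreadable from compound 1 to compound 2 and a step that the two limits leave unreadable from compound 1 to compound 3, and between those two products a step that the two limits leave unreadable from compound 2 to compound 3. None of them can be sized: both ends of each step sit at limits, the limit of > 20800 nM in this assay, at which 1 of the 3 values shown sits, and the limit of > 21900 nM in this assay, at which 1 of the 3 values shown sits, among them. With all three values at limits, no step beyond the scatter can be read in either direction, and compound 4 is expected to show a step that the limit leaves unreadable from compound 1 to compound 4, most likely as another limit. The estimate for compound 4 is 30000 nM, between 10000 nM and 100000 nM.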

Compound 4, half-maximal effective concentration: > 26000 nM
Compound 4 gave a limit, no number; the forecaster's own chance of this, stated with the estimate: 80%; the middle value does not contradict the limit.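

Going by these compounds alone, compound 4, like compounds 1, 2 and 3, gives only a limit and no number, so no step between compound 4 and any of the others can be read. The compounds shown leave open what concentration in this assay produces the effect for any of the four, and so whether these changes make any difference.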